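A Methoxy Added to the Fused Ring System

This account rests on a few compounds, and the source may have more. Where it says the series, first, only, none or still open, it means among the compounds named here.

compound 1 `CCOC(=O)c1c(-c2cc3ccccc3oc2=O)nn(-c2ccc(OC)cc2)c1C(=O)OCC`: 86000 nM
compound 2 `CCOC(=O)c1c(-c2cc3ccccc3oc2=O)nn(-c2cccc(Cl)c2)c1C(=O)OCC`: 28000 nM

In a functional assay on A549 cells (Homo sapiens) for cytotoxicity, read by MTT assay, with a stated time of 48 h (a lower number here means a stronger inhibitor, a higher number a weaker inhibitor), compound 1 gives 86000 nM and compound 2 gives 28000 nM. Going by the values given here, compound 2 thus stands lowest of the two numbers, the only known step being a 3.1-fold lower number from compound 1 to compound 2 (0.49 log units; beyond the scatter). Compound 3 `CCOC(=O)c1c(-c2cc3ccc(OC)cc3oc2=O)nn(-c2cccc(Cl)c2)c1C(=O)OCC` differs from compound 2 by methoxy in place of hydrogen on an aromatic carbon. Among the compounds with values here, no measured step touches this part of the shared core; the one known step swaps the group on the aromatic nitrogen instead, so it offers no guidance. A change no larger than the scatter is therefore expected, namely no change at the digits printed from compound 2 to compound 3 (within the scatter). Compound 3 is estimated at 28000 nM, within 9000 nM to 90000 nM.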

Compound 3, half-maximal inhibitory concentration: 221000 nM
For compound 3 the middle estimate is 7.9-fold (0.90 log units) below the measured one; the whole stated range lies below it.
By their numbers in this assay, from the lowest: compound 2; then compound 1; then compound 3.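

In this assay, the part of the shared core that carries the new group proves sensitive to change: a 7.9-fold higher number from compound 2 to compound 3 (0.90 log units; beyond the scatter) comes with methoxy in place of hydrogen on this aromatic carbon. This single small addition moves compound 3 towards weaker inhibition, so this carbon is not a neutral place to add a group. No available evidence accounts for this loss. The compounds shown leave open whether any group here would do the same, or only methoxy. A fluorine atom, a hydroxyl or an amine on this carbon would help separate the two.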